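From isobutyl to butyl on a sulfonamide nitrogen

The compounds below may be only part of what the source reports. "The series", "measured", "known", "first", "only" and "open" are said of these compounds alone.

- compound 1 `CCC1C(=O)N(C)c2cnc(Nc3ccc(S(=O)(=O)NCC(C)C)cc3)nc2N1c1ccn(C)n1` reads 31600 nM
- compound 2 `CCC1C(=O)N(C)c2cnc(-n3ccc4cc(F)ccc43)nc2N1c1ccn(C)n1` reads "not active" (no number reported)

These readings come from a functional assay on A549 cells (Homo sapiens) for antiproliferative activity, read by CCK-8 assay, with a stated time of 72 h (a lower number here means a stronger inhibitor of growth, a higher number a weaker inhibitor of growth), and only compound 1 carries a number there, so it has no other value to be ranked against. Compound 2 was reported without a number. Compound 3 `CCCCNS(=O)(=O)c1ccc(Nc2ncc3c(n2)N(c2ccn(C)n2)C(CC)C(=O)N3C)cc1` has not yet been measured. It differs from compound 1 as follows propyl in place of isopropyl on a saturated chain carbon bound to a sulfonamide nitrogen with propyl in place of isopropyl on a saturated chain carbon bound to a sulfonamide nitrogen, which reads as isobutyl to butyl when cut one bond further out. Among the measured compounds shown here, no measured pair shows what such a change does, so no step beyond the usual scatter is expected in this assay and no direction is favoured. The estimated 1.1-fold lower number from compound 1 to compound 3 (0.02 log units; within the scatter) therefore stays small. Compound 3 is expected at 30000 nM with a range from 12000 nM to 75000 nM in this estimate.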

Compound 3, concentration for 50% growth inhibition: 10600 nM
The estimate for compound 3 lay 2.8-fold (0.45 log units) above the measured number; the whole stated range lies above it.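

In this assay, butyl in place of isobutyl on the sulfonamide nitrogen gives a 3.0-fold lower number from compound 1 to compound 3 (0.47 log units; beyond the scatter) and thus a step beyond the scatter, although the two compounds have the same atoms, joined differently. This first measured step at this place shows that the activity of the series responds to the arrangement of the chain on the sulfonamide nitrogen, not only to its atom count, and that the unbranched butyl is the better of the two chains here. No measured information bears on why the step occurs.

Going by these compounds, whether a longer chain such as pentyl would extend the step remains open. So does the effect of a ring such as cyclopropylmethyl or of an amine at the end of the chain.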